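A few compounds are considered here, and "the series" means these few. Any claim that something is new, unique, unknown or untested is made for them only; others in the source may bear on it.

In a functional assay on C6 cells (Rattus norvegicus) for cytotoxicity, read by MTT assay, with a stated time of 24 h, tested at 100 ug/mL (a higher number here means a weaker effect of the compound at the concentration tested, a lower number a stronger effect), compound 1 `Cc1nnc(SCC(=O)N/N=c2/scc(-c3ccc(F)cc3)n2-c2ccccc2)s1` gives 34.9% and compound 2 `Cc1nnc(SCC(=O)N/N=c2/scc(-c3ccc(Cl)cc3)n2-c2ccccc2)s1` gives 34.1%. Among the compounds with values here, the only step so far, a number 0.8 percentage points lower from compound 1 to compound 2 (within the scatter), comes from chloro in place of fluoro on an aromatic carbon. Of the two numbers, compound 2 stands at the lower one, the gap to compound 1 being within the scatter. Compound 3 `O=C(CSc1nnnn1-c1ccccc1)N/N=c1/scc(-c2ccc(Cl)cc2)n1-c1ccccc1` differs from compound 2 by 1-phenyl-1H-tetrazol-5-yl in place of 5-methyl-1,3,4-thiadiazol-2-yl on a sulfur. Within the data shown here, no measured step touches the group on the sulfur, so the halide step offers no guide to size or direction here. The expected step of a number 0.9 percentage points higher from compound 2 to compound 3 (within the scatter) is therefore none beyond the scatter, with a wide range. Compound 3 is estimated at 35%, between 15% and 60%.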

Compound 3, a percentage reported as activity, at one concentration (the size of the read-out at that concentration, not a potency): 54.3%
Beside the measured number, compound 3's estimate is 19.3 percentage points below it, within the range that was stated.
By their numbers in this assay, from the lowest: compounds 2 and 1 (each within the scatter of the next); then compound 3.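

In this assay, within the data shown here, the group on the sulfur is the first place where a change moves the read-out beyond the scatter: a number 20.2 percentage points higher from compound 2 to compound 3 (beyond the scatter), which means a weaker effect at the concentration tested. Among these compounds, the one halide step stayed within the scatter, so this single pair marks the sulfur position as the more responsive of the two places changed. No measurement shown accounts for the step. Going by these compounds, the change swaps the five-membered ring and adds a phenyl at once, so which of the two carries the step stays open. A 1-methyl-1H-tetrazol-5-yl group on the sulfur would separate them.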